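This account rests on a few compounds, and the source may have more. Where it says the series, first, only, none or still open, it means among the compounds named here.

Measured in a functional assay on KYSE-450 cells (Homo sapiens) for inhibition, read by MTT assay, with a stated time of 48 h; a lower number here means a stronger inhibitor, a higher number a weaker inhibitor:
- Compound 1 `COCC(=O)N(Cc1ccc(OC)c(O)c1)c1cc(OC)c(OC)c(OC)c1`: 460 nM
- Compound 2 `COc1ccc(CN(C(=O)C=C(C)C)c2cc(OC)c(OC)c(OC)c2)cc1O`: 280 nM
- Compound 3 `CC/C=C/C(=O)N(Cc1ccc(OC)c(O)c1)c1cc(OC)c(OC)c(OC)c1`: 72 nM

Compound 3 has the lowest number of the three, at 72 nM. The measured steps to it are a 6.4-fold lower number from compound 1 to compound 3 (0.81 log units; beyond the scatter) and a 3.9-fold lower number from compound 2 to compound 3 (0.59 log units; beyond the scatter). Compound 4 `COc1ccc(CN(C(=O)CN=[N+]=[N-])c2cc(OC)c(OC)c(OC)c2)cc1O` has azidomethyl in place of but-1-en-1-yl on a carbonyl carbon.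

For the measured compounds named here, no measured compound carries azidomethyl, so the comparison is indirect. The closest measured group is methoxymethyl in compound 1, which also holds atoms other than carbon. The step that bears most directly is therefore a 6.4-fold lower number from compound 1 to compound 3 (0.81 log units; beyond the scatter), and the change to compound 4 runs roughly the opposite way. a 1.6-fold lower number from compound 1 to compound 2 (0.22 log units; within the scatter) adds a caution, since that alkenyl change did not clearly alter the number. A modest step to a higher number in this assay is thus expected. The expected step is a 5.3-fold higher number from compound 3 to compound 4 (0.72 log units; beyond the scatter). For compound 4, the estimated value is 380 nM, with an expected range of 130 nM to 1100 nM.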

Compound 4, half-maximal inhibitory concentration: 160 nM
Compound 4: middle estimate off by 2.4-fold (0.38 log units), on the high side, within the range that was stated.
By their numbers in this assay, from the lowest: compound 3; then compounds 4, 2 and 1 (each within the scatter of the next, the first and the last beyond it).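

Azidomethyl shows that this carbonyl carbon can carry a chain without a carbon-carbon double bond and still differ from methoxymethyl, since azido in place of methoxy on the saturated chain carbon bound to the carbonyl carbon gives a modest gain in this assay (a 2.9-fold lower number from compound 1 to compound 4 (0.46 log units; beyond the scatter)). Compound 3 nonetheless keeps its lead, as the change to azidomethyl costs a modest amount (a 2.2-fold higher number from compound 3 to compound 4 (0.35 log units; beyond the scatter)), while azidomethyl and 2-methylprop-1-en-1-yl cannot be told apart (a 1.8-fold lower number from compound 2 to compound 4 (0.24 log units; within the scatter)). The substituents at this position therefore do not separate simply into alkenyl and non-alkenyl groups, and no measurement shown explains the differences among them.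

From the compounds shown here alone, it remains open whether the lead of compound 3 depends on its double bond, which a saturated butyl chain on the same carbonyl carbon would test. Going by these compounds, how an aminomethyl group would compare also remains open.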